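Methoxy in Place of Fluoro on the Benzyl Arm

This account rests on a few compounds, and the source may have more. Where it says the series, first, only, none or still open, it means among the compounds named here.

In an ADME assay on RAW264.7 cells (Mus musculus) for cytotoxicity, read by MTT assay, with a stated time of 72 h, tested at 50 uM (a lower number here means less inhibition, a higher number more inhibition at the concentration tested (going by the name of the read-out)), compound 3 `CCOC(=O)c1sc(-c2ccccn2)nc1N1CCC(NCc2ccc(F)cc2)CC1` gives 12.6%. That is the second highest of three numbers: compound 2 `CCOC(=O)c1sc(-c2ccccn2)nc1N1CCC(NCc2ccccc2)CC1` gives 14.6%, and compound 1 `CCOC(=O)c1sc(-c2ccccc2)nc1N1CCC(NCc2ccc(OC)cc2)CC1` gives 8.4%, and both of these lie within the scatter of compound 3. Compound 4 `CCOC(=O)c1sc(-c2ccccn2)nc1N1CCC(NCc2ccc(OC)cc2)CC1` differs from compound 3 by methoxy in place of fluoro on an aromatic carbon. For the measured compounds named here, no measured step swaps exactly these two groups. Going by the values given here, the only single-place step available, a number 2 percentage points lower from compound 2 to compound 3 (within the scatter), stayed within the scatter, and compound 1, which carries the 4-methoxybenzyl group on a different core, also sits within the scatter of compound 3. No step beyond the scatter is therefore expected in this assay. Compound 4 is estimated at 11%, between 2% and 22%, which means an expected step of a number 1.6 percentage points lower from compound 3 to compound 4 (within the scatter).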

Compound 4, a percentage reported as inhibition, at one concentration (the size of the read-out at that concentration, not a potency): 4.62%
Estimate against measurement, compound 4: 6.4 percentage points above; the range from low to high includes it.
By their numbers in this assay, from the lowest: compounds 4, 1, 3 and 2 (each within the scatter of the next).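

In this assay, 4-methoxybenzyl can now be compared directly with 4-fluorobenzyl (the step is a number 8 percentage points lower from compound 3 to compound 4 (within the scatter)) and with plain benzyl (the step is a number 10 percentage points lower from compound 2 to compound 4 (within the scatter)), and neither change moves the number beyond the scatter. The same holds for pyridin-2-yl in place of phenyl on the core, now seen on its own with the 4-methoxybenzyl arm held fixed (the step is a number 3.8 percentage points lower from compound 1 to compound 4 (within the scatter)). No measurement offered here explains these numbers.

On these data alone, whether an amine or a carboxylic acid at this position on the benzyl ring would give a step beyond the scatter remains open. So does the effect of a longer chain between the ring and the nitrogen.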